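Removing the bromo group: from compound 2 to compound 3

This account rests on a few compounds, and the source may have more. Where it says the series, first, only, none or still open, it means among the compounds named here.

Compound 2 `COc1cc(C2CC(c3ccc(Br)cc3)=NN2C(C)=O)ccc1OCc1cn(Cc2ccc([N+](=O)[O-])cc2)nn1` gives 0% in a functional assay on A549 cells (Homo sapiens) for inhibition, read by sulforhodamine B assay, tested at 10 uM (on this read-out lower numbers stand for less inhibition of growth and higher numbers for more inhibition of growth at the one concentration tested), the lowest of the two numbers measured. The other measured compound, compound 1 `COc1cc(C2CC(c3ccc([N+](=O)[O-])cc3)=NN2C(C)=O)ccc1OCc1cn(Cc2ccc([N+](=O)[O-])cc2)nn1`, gives 39% in this assay. Going by the values given here, the only measured step, a number 39 percentage points lower from compound 1 to compound 2 (beyond the scatter), covers a different exchange, bromo in place of nitro on an aromatic carbon, and shows how strongly this position can matter.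

Compound 3 `COc1cc(C2CC(c3ccccc3)=NN2C(C)=O)ccc1OCc1cn(Cc2ccc([N+](=O)[O-])cc2)nn1` is the next member: hydrogen in place of bromo on an aromatic carbon. Among the compounds with values here, no measured step covers the loss of a bromo group, so the one step measured offers only an indirect guide. Since the bromo compound 2 already sits at the bottom of the scale with 0%, the expected step of a number 8 percentage points higher from compound 2 to compound 3 (within the scatter) is small, no change beyond the scatter or at most a slight rise. Compound 3 is therefore estimated at 8% in this assay, with a range from 0% to 25%.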

Compound 3, percent growth inhibition at one concentration: 0%
The estimate for compound 3 lay 8 percentage points above the measured number, and the stated range covers the measured number.
By their numbers in this assay, from the lowest: compounds 2 and 3 (each within the scatter of the next); then compound 1.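

Hydrogen in place of bromo gives no change at the digits printed from compound 2 to compound 3 (within the scatter) in this assay, so at this position on the ring, the bromo group and a plain hydrogen cannot be told apart in this read-out. The second comparison gives a number 39 percentage points lower from compound 1 to compound 3 (beyond the scatter), which shows that the unsubstituted phenyl compound also lacks the growth inhibition seen with the nitro group. Among the three compounds, then, only compound 1, with its nitro group, shows growth inhibition at the one concentration tested, while the bromo and hydrogen compounds both sit at the bottom of the scale.

Going by these compounds, whether an amine, a carboxylic acid or a nitrile at this position would match compound 1 remains open. Nothing available here explains why the nitro compound stands apart.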